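The compounds below may be only part of what the source reports. "The series", "measured", "known", "first", "only" and "open" are said of these compounds alone.

The measured compounds:

Compound 1 `O=S(=O)(NCCCNc1nccc(-c2c(-c3cccc(F)c3)nc3sccn23)n1)c1cccc(F)c1` gives 13700 nM in a functional assay on A-375 cells (Homo sapiens) for cytotoxicity, read by MTT assay; on this read-out higher numbers stand for weaker inhibition and lower numbers for stronger inhibition.
Compound 2 `O=S(=O)(NCCCNc1nccc(-c2c(-c3cccc(F)c3)nc3sccn23)n1)c1ccc(Cl)cc1` gives 5900 nM in this assay.
Compound 3 `O=C(NCCNc1nccc(-c2c(-c3cccc(F)c3)nc3sccn23)n1)c1ccc(C(F)(F)F)cc1` gives 8710 nM in this assay.

Compound 3 stands second highest of the three numbers; its nearest neighbour is compound 2, and its furthest is compound 1, and both of those gaps fall within the usual scatter, so nothing can be said about an order among them.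

Compound 4 `O=C(NCCNc1nccc(-c2c(-c3cccc(F)c3)nc3sccn23)n1)c1ccc(Cl)cc1` is made from compound 3 by one change: chloro in place of trifluoromethyl on an aromatic carbon. Among the compounds with values here, only one measured step has a bearing on this, and only loosely: a 2.3-fold lower number from compound 1 to compound 2 (0.37 log units; beyond the scatter), where a 4-chlorophenyl came in on a different part of the molecule. That step was modest, and the change from a trifluoromethyl to a chloro is not the same exchange, so no strong movement is expected in this assay for compound 4. The step from compound 3 to compound 4 is estimated as a 1.3-fold lower number from compound 3 to compound 4 (0.13 log units; within the scatter), a small shift toward a lower number. Compound 4 is thus expected to give about 6500 nM, within a range of 3000 nM to 14000 nM.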

Compound 4, half-maximal inhibitory concentration: 2570 nM
The estimate for compound 4 lay 2.5-fold (0.40 log units) above the measured number, and the stated range ends above it.
By their numbers in this assay, from the lowest: compound 4; then compounds 2, 3 and 1 (each within the scatter of the next, the first and the last beyond it).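

In this assay, the change from 4-(trifluoromethyl)phenyl to 4-chlorophenyl gives a 3.4-fold lower number from compound 3 to compound 4 (0.53 log units; beyond the scatter) and so shows that the number responds to the group at this ring position, even with one heavy atom in place of four. With 4-chlorophenyl kept, replacing the sulfonyl-bearing end of the chain with the carbonyl-bearing end gives a 2.3-fold lower number from compound 2 to compound 4 (0.36 log units; beyond the scatter) and shows that this part matters too, while the wider a 5.3-fold lower number from compound 1 to compound 4 (0.73 log units; beyond the scatter) also includes the change of aromatic group. Nothing measured here explains either shift.

On these data alone, since the step to compound 4 from compound 2 changes both the sulfonyl and the chain, the effect of each alone remains open. As far as these compounds go, it is also open how a methoxy group or an amine would compare with chloro at this ring position.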